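The compounds below may be only part of what the source reports. "The series", "measured", "known", "first", "only" and "open" are said of these compounds alone.

Measured compounds:
Compound 1 `O=C(Nc1cccc(-n2cc(-c3ccncc3)c(-c3ccc(Cl)c(O)c3)n2)c1)Nc1cccc(C(F)(F)F)c1` gives 13700 nM in a functional assay on OVCAR-5 cells (Homo sapiens) for inhibition, read by sulforhodamine B assay, with a stated time of 48 h; a higher number here means a weaker inhibitor of growth, a lower number a stronger inhibitor of growth.
Compound 2 `COc1cc(-c2nn(-c3cccc(NC(=O)c4cccc(C(F)(F)F)c4)c3)cc2-c2ccncc2)ccc1Cl` gives 4010 nM in this assay.

Compound 2 carries the lowest number of the two measured. Compound 1 sits higher, and the gap between them lies beyond the scatter, though the two structures differ in more than one place, so no single change can be read from that pair. Compound 3 `COc1cc(-c2nn(-c3cccc(NC(=O)Nc4cccc(C(F)(F)F)c4)c3)cc2-c2ccncc2)ccc1Cl` has not yet been measured. Compared with compound 2, compound 3 has (3-(trifluoromethyl)phenyl)amino in place of 3-(trifluoromethyl)phenyl on a carbonyl carbon. For the measured compounds named here, no pair of measured compounds shows this change alone, so its effect is unknown here. The step from compound 2 to compound 3 is expected to be modest, and if anything toward a higher number, given that the carbonyl-linked group of compound 3 is otherwise carried only by compound 1, which gives 13700 nM. Compound 3 is therefore expected to give about 6500 nM, within a range of 2000 nM to 20000 nM, for an estimated step of a 1.6-fold higher number from compound 2 to compound 3 (0.21 log units; within the scatter).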

Compound 3, concentration for 50% growth inhibition: 1270 nM
Compound 3: the middle estimate sits 5.1-fold (0.71 log units) above what was measured; the measured number lies below the stated range.
By their numbers in this assay, from the lowest: compound 3; then compound 2; then compound 1.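

On the carbonyl carbon, (3-(trifluoromethyl)phenyl)amino in place of 3-(trifluoromethyl)phenyl gives a 3.2-fold lower number from compound 2 to compound 3 (0.50 log units; beyond the scatter) in this assay, so this single change now has a readable effect, and it lies beyond the scatter. Compound 3 also makes a second comparison possible: methyl in place of hydrogen on an oxygen on an aromatic ring gives an 11-fold lower number from compound 1 to compound 3 (1.03 log units; beyond the scatter), a large step in the same assay. Nothing measured here offers a reason for either step.

From the compounds shown here alone, each change is seen only once, so it remains open whether the methyl step would hold with the 3-(trifluoromethyl)phenyl group on the carbonyl carbon. Also open, going by these compounds, is how an ethyl group on that oxygen, or an oxygen or a methylene in place of the amino link, would compare with compound 3.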